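Methoxy Entry on the Chlorophenyl Side of Compound 3

This account rests on a few compounds, and the source may have more. Where it says the series, first, only, none or still open, it means among the compounds named here.

Measured compounds:
compound 1, `Cc1cc(NC(=O)Nc2ccc(C)c(Cl)c2)c2ccccc2n1`: > 25000 nM
compound 2, `COc1ccc(NC(=O)Nc2cc(C)nc3ccccc23)cc1`: > 25000 nM
compound 3, `Cc1cc(NC(=O)Nc2cccc(Cl)c2)c2ccccc2n1`: 18000 nM

Three ureas have been tested in an ADME assay on Raji cells (Homo sapiens) for cytotoxicity, with a stated time of 72 h; on this read-out lower numbers stand for an effect already at smaller amounts and higher numbers for an effect only at larger amounts of compound. For compound 1 the result is a limit of the assay, > 25000 nM. For compound 2 the result is likewise only a limit, > 25000 nM. Compound 3 alone gives an actual number, 18000 nM, so it is the one fixed point among the three. Going by the values given here, the single measured step, an at least 1.3-fold lower number from compound 1 to compound 3 (0.14 log units; that floor lies within the scatter), concerns a methyl and stays within the scatter.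

Compound 4, `COc1ccc(NC(=O)Nc2cc(C)nc3ccccc23)cc1Cl`, differs from compound 3 by methoxy in place of hydrogen on an aromatic carbon. Among the compounds with values here, no measured step covers this change. Compound 2 carries a methoxy and sits at the limit, whereas compound 3 gives a number; since the two are not a single-point pair, their values show only that much. Given (the limit of > 25000 nM in this assay, at which 2 of the 3 values shown sit), the step of a 1.4-fold higher number from compound 3 to compound 4 (0.14 log units; within the scatter) is expected to be small or to run toward that limit. Compound 4 is therefore expected to give 25000 nM in this assay, with a range from 9000 nM to 70000 nM.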

Compound 4, half-maximal effective concentration: > 25000 nM
Compound 4 ended at the assay's limit; the forecaster's own chance of this, stated with the estimate: 60%; the middle value sits exactly at the limit.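

In this assay, methoxy in place of hydrogen, ortho to a chloro group and para to a large group, gives an at least 1.3-fold higher number from compound 3 to compound 4 (0.14 log units; that floor lies within the scatter). Going by these compounds alone, this is the first look at a change at this place on the chlorophenyl side, and it brings no lower number, though the printed step is only a floor and its true size stays unknown. The steps from compound 2 and from compound 1 to compound 4 cannot be read, so neither the chloro group nor the swap of methyl for methoxy shows a size of its own: the limit of > 25000 nM in this assay, at which 3 of the 4 values shown sit.

The compounds shown leave open whether an amine or a carboxylic acid at this same place would give an actual number rather than a limit. They also leave open whether an ethoxy group, with its longer chain, would behave as methoxy does here.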